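Sulfonylguanidine series: benzyl substituent swap, cytotoxicity notes

The source may report more compounds than this note shows. Statements on the series, on what has been measured and on what is new or still open speak of the compounds shown alone.

Measured so far:
compound 1, `Cc1cccc(CSc2cc(Cl)c(C)cc2S(=O)(=O)/N=C(\N)n2nccc2-c2ccccc2)c1`: 6500 nM
compound 2, `Cc1cc(-c2ccccc2)n(/C(N)=N/S(=O)(=O)c2cc(C)c(Cl)cc2SCc2cccc(C(F)(F)F)c2)n1`: 19000 nM

In a functional assay on HCT-116 cells (Homo sapiens) for cytotoxicity, read by MTT assay, with a stated time of 72 h (on this read-out higher numbers stand for weaker inhibition and lower numbers for stronger inhibition), compound 2 gives 19000 nM, the highest of the two numbers in hand; its nearest neighbour is compound 1, which gives 6500 nM, a gap beyond the scatter. Within the data shown here, no single-change step between the two measured compounds is available, since they differ in more than one place.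

Compound 3, `Cc1cccc(CSc2cc(Cl)c(C)cc2S(=O)(=O)/N=C(\N)n2nc(C)cc2-c2ccccc2)c1`, is not yet measured. It differs from compound 2 in one place: methyl in place of trifluoromethyl on an aromatic carbon. Compound 3 thereby carries the 3-methylbenzyl group that compound 1 also carries, while keeping the core of compound 2. With no measured step for this exchange, the expectation rests on the two numbers shown: the compound bearing the 3-methylbenzyl group, compound 1, sits lower than compound 2. The step from compound 2 to compound 3 is therefore expected to run downward, by a modest margin at most, as a 1.9-fold lower number from compound 2 to compound 3 (0.28 log units; within the scatter). Compound 3 is estimated at 10000 nM, with a range from 4000 nM to 25000 nM.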

Compound 3, half-maximal inhibitory concentration: 34000 nM
Compound 3: the middle estimate sits 3.4-fold (0.53 log units) below what was measured; the measured number lies above the stated range.
By their numbers in this assay, from the lowest: compound 1; then compounds 2 and 3 (each within the scatter of the next).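

In this assay, a 1.8-fold higher number from compound 2 to compound 3 (0.25 log units; within the scatter), so on this benzyl position, with the core of compound 2 held fixed, 3-(trifluoromethyl)benzyl and 3-methylbenzyl cannot be told apart, and the exchange of trifluoromethyl for methyl meta to a large group gives no readable change in cytotoxicity. The other single change gives a clearer result: a 5.2-fold higher number from compound 1 to compound 3 (0.72 log units; beyond the scatter), a step beyond the scatter that marks methyl in place of hydrogen on an aromatic carbon of the core as the one change among these compounds with a readable weakening, though it rests on this single pair. Nothing at hand bears on why the first step stays within the scatter or why the second goes beyond it.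

As far as these compounds go, it remains open whether methyl in place of hydrogen on the core gives a step of similar size when the benzyl group is 3-(trifluoromethyl)benzyl rather than 3-methylbenzyl. The compounds shown also leave open whether the flat response on the benzyl ring extends to an amine, a carboxylic acid or a longer alkyl chain at the same place.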